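Aryl-alkenyl ether series on pancreatic carcinoma cells

The source may hold more compounds than are shown below. What is called first, only, known or untested is meant among the compounds shown, and "the series" means these compounds.

Measured so far:
compound 1 `CC(C)(C)OC(=O)N1CCC[C@H]1COCCCCCCCC/C=C/c1ccc(-c2ccccc2)cc1`: 90000 nM
compound 2 `CC(C)(C)OC(=O)N1CCC[C@H]1COCCCCCCCC/C=C/c1ccc(Oc2ccccc2)cc1`: 90000 nM
compound 3 `CC(=O)N1CCC[C@H]1COCCCCCCCCC/C=C/c1ccc(-c2ccccc2)cc1`: 70000 nM

All three were run in a functional assay on PANC-1 cells (Homo sapiens) for inhibition, read by XTT assay, with a stated time of 72 h; on this read-out higher numbers stand for weaker inhibition and lower numbers for stronger inhibition. Compound 1 and compound 2 share a core and differ only at the far end of the chain; the change is phenoxy in place of phenyl on an aromatic carbon. The step of no change at the digits printed from compound 1 to compound 2 (within the scatter) shows this exchange leaves the read-out where it was. Compound 3 stands on a different core; the difference between the core of compound 3 and the core of compound 1 is not broken down here. In this assay compound 3 gives a number that lies within the scatter of compound 1 and of compound 2, so no order among the three can be claimed.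

Compound 4 `CC(=O)N1CCC[C@H]1COCCCCCCCCC/C=C/c1ccc(Oc2ccccc2)cc1` is not yet measured. It relates to compound 3 exactly as compound 2 relates to compound 1: the change is phenoxy in place of phenyl on an aromatic carbon, the same change at the same place. Since the step of no change at the digits printed from compound 1 to compound 2 (within the scatter) was flat, the step from compound 3 to compound 4 is expected to be about as small, no change at the digits printed from compound 3 to compound 4 (within the scatter). On that basis compound 4 is estimated at 70000 nM in this assay, with a range from 35000 nM to 140000 nM.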

Compound 4, half-maximal inhibitory concentration: 65000 nM
The estimate for compound 4 lay 1.1-fold (0.03 log units) above the measured number; the range from low to high includes it.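

In this assay, the new step reads a 1.1-fold lower number from compound 3 to compound 4 (0.03 log units; within the scatter), so phenoxy in place of phenyl on an aromatic carbon also leaves the read-out flat on the second core. Set beside the earlier step, the exchange carries over between the two cores with no difference that can be told from scatter: the same change on two cores in this assay, no change at the digits printed (within the scatter) from compound 1 to compound 2 and a 1.1-fold lower number (0.03 log units; within the scatter) from compound 3 to compound 4, 1.1-fold (0.03 log units) apart, within the scatter of two such steps. This shows that the exchange is silent on these two cores at these weak numbers; it does not show that it would stay silent on a core with a much stronger read-out, and it gives no reason for the flatness.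

Still open, on these data alone, is whether a different group on the same aromatic carbon, such as an amine or a carboxylic acid, would move the number beyond the scatter. As far as these compounds go, compound 1 and compound 3 differ in more than one place, so what each of those differences contributes, including that of a longer chain, also stays open.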